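Extending the sulfonyl chain from compound 2 to compound 4

The compounds below may be only part of what the source reports. "The series", "measured", "known", "first", "only" and "open" are said of these compounds alone.

Values measured so far in a physicochemical assay for lipophilicity; on this read-out lower numbers stand for lower lipophilicity and higher numbers for higher lipophilicity
compound 1 `CCCCCCS(=O)(=O)c1ccc(O)c(C(=O)Nc2ccc(Br)cc2)c1` gives 5.2
compound 2 `CCCCS(=O)(=O)c1ccc(O)c(C(=O)Nc2ccc(C(F)(F)F)cc2)c1` gives 4.14
compound 3 `CCCCCCCCCCS(=O)(=O)c1ccc(O)c(C(=O)Nc2ccc(Br)cc2)c1` gives 7.36

Compound 2 stands lowest of these three numbers. Compound 1 is the nearest above it and compound 3 the furthest, both beyond the usual scatter. Compounds 1 and 2 differ in more than one place, so their gap does not isolate any single change.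

Compound 4 `CCCCCCCCCCCCS(=O)(=O)c1ccc(O)c(C(=O)Nc2ccc(C(F)(F)F)cc2)c1` is reached from compound 2 by a single change: octyl in place of hydrogen on a saturated chain carbon, four bonds along the chain from a sulfonyl sulfur.

Among the measured compounds shown here, one measured step bears on this: a number 2.16 log units higher from compound 1 to compound 3 (beyond the scatter). It is large, and it comes from butyl in place of hydrogen on a saturated chain carbon, six bonds along the chain from a sulfonyl sulfur. For the measured compounds named here, that step was measured on compounds carrying bromine, whereas compound 2 carries trifluoromethyl, and no chain step has been measured with that group. Going by a number 2.16 log units higher from compound 1 to compound 3 (beyond the scatter), an upward step larger than that one is expected in this assay, scaled to the longer octyl group. This scaling rests on one step only.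

The estimated step runs a number 4.32 log units higher from compound 2 to compound 4 (beyond the scatter). The expected value for compound 4 is 8.46, with an estimated range from 7.9 to 8.9.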

Compound 4, partition coefficient: 8.46
Compound 4: middle estimate and measured number agree at the digits printed; low and high end bracket the measured number.
By their numbers in this assay, from the lowest: compound 2; then compound 1; then compound 3; then compound 4.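

In this assay, the effect of extending the sulfonyl chain can now be read on a compound carrying trifluoromethyl as well as on one carrying bromine: octyl in place of hydrogen on a saturated chain carbon, four bonds along the chain from a sulfonyl sulfur, gives a number 4.32 log units higher from compound 2 to compound 4 (beyond the scatter). Set beside a number 2.16 log units higher from compound 1 to compound 3 (beyond the scatter), which comes from adding butyl to a longer chain, this step also runs upward and is the larger of the two, so the added carbon count and the size of the rise go together across these two steps, and no compound shown goes against this. The pairing remains loose, as the two steps start from different chains and carry different groups on the core, so it does not separate chain length from either of those differences.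

On these data alone, it remains open whether a longer chain would continue the rise, and how a chain ending in an amine or a carboxylic acid would read in this assay. No measurement shown here accounts for the size of either step.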